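The source may report more compounds than this note shows. Statements on the series, on what has been measured and on what is new or still open speak of the compounds shown alone.

Compound 1, with the structure `ClCc1ccccc1Cn1cnc2c(Cl)nc(Cl)nc21`, is tested in a functional assay on KM12 cells (Homo sapiens) for cytotoxicity, read by sulforhodamine B assay, with a stated time of 48 h (on this read-out higher numbers stand for weaker inhibition of growth and lower numbers for stronger inhibition of growth), where it gives 2950 nM. Of the two measured numbers this is the highest; compound 2, with the structure `ClCc1ccc(Cn2cnc3nc(Cl)nc(Cl)c32)cc1`, gives 670 nM in this assay, a difference beyond the usual scatter. Compound 3, with the structure `Nc1nc(Cl)c2ncn(Cc3ccccc3CCl)c2n1`, is not yet measured. It differs from compound 1 in one place: amino in place of chloro on an aromatic carbon. Among the measured compounds shown here, no measured pair shows this change, so the expected step from compound 1 to compound 3 is a 1.5-fold higher number from compound 1 to compound 3 (0.18 log units; within the scatter), a small move toward weaker growth inhibition at most. Compound 3 is therefore expected to give about 4500 nM in this assay, within a range from 1200 nM to 18000 nM.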

Compound 3, concentration for total growth inhibition: 38900 nM
Compound 3: the middle estimate sits 8.6-fold (0.94 log units) below what was measured, and the stated range ends below it.
By their numbers in this assay, from the lowest: compound 2; then compound 1; then compound 3.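

The carbon between two ring nitrogen atoms is not indifferent to what it carries: amino in place of chloro there gives a 13-fold higher number from compound 1 to compound 3 (1.12 log units; beyond the scatter) and so a large move toward weaker growth inhibition. Compounds 1 and 2 both keep chloro at this carbon, so they could not show this sensitivity. What lies behind the loss is not explained by any data at hand. Open, on these data alone, is whether a methoxy or dimethylamino group on this carbon would track chloro or amino. Also open, as far as these compounds go, is whether the same change would cost as much in compound 2.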